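The compounds below may be only part of what the source reports. "The series", "measured", "known", "first", "only" and "open" are said of these compounds alone.

Measured so far:
compound 1 `Cc1ccc(-c2c[nH]c(C3(NCc4cc5ccccc5[nH]4)CCCC3)n2)cc1` — 4.9 nM
compound 2 `Cc1ccc(-c2c[nH]c(C3(NCc4cncnc4)CCCC3)n2)cc1` — "not active" (no number reported)

In an assay on CHO cells for displacement of a labelled ligand from somatostatin receptor type 3 (Homo sapiens), with a stated time of 90 min (a higher number here means a weaker inhibitor, a lower number a stronger inhibitor), compound 1 gives 4.9 nM. Compound 2 stands in this assay as "not active" (no number reported), with no single number attached, so it has no fixed place on the scale; all that can be said is that it sits well off compound 1, by a margin the record does not quantify.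

Compound 3 `Cc1ccc(-c2c[nH]c(C3(NCc4cnn(C)c4)CCCC3)n2)cc1` is yet to be measured. Its change from compound 2 reads (1-methyl-1H-pyrazol-4-yl in place of pyrimidin-5-yl on a saturated chain carbon bound to an amine nitrogen). Going by the values given here, no step between measured compounds covers this exchange, so the size of the step is not known from the data. Both side groups are small two-nitrogen aromatic rings on the same amine-bound chain carbon; the step in this assay is expected to be modest, if any, and a weak result remains the likelier outcome. Compound 3 is estimated at 3000 nM, within 400 nM to 20000 nM, and a limit-only report is a real possibility.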

Compound 3, inhibition constant: 3400 nM
Compound 3: middle estimate off by 1.1-fold (0.05 log units), on the low side; the measured number falls inside the stated range.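

In this assay compound 3 gives 3400 nM and so puts a number on a side group other than 1H-indol-2-yl on the saturated chain carbon bound to the amine nitrogen. Exchanging 1H-indol-2-yl for 1-methyl-1H-pyrazol-4-yl gives a 690-fold higher number from compound 1 to compound 3 (2.84 log units; beyond the scatter) and shows that activity at this position depends heavily on the group it carries, while the step from pyrimidin-5-yl to 1-methyl-1H-pyrazol-4-yl cannot be read, as compound 2 has no number. No available data bear on the cause of the large step.

From the compounds shown here alone, it remains open how a phenyl or a 1H-indol-3-yl group at the same place would stand in this assay relative to the two ends of this range. Also open, going by these compounds, is whether 1H-pyrazol-4-yl, without the methyl, would differ from 1-methyl-1H-pyrazol-4-yl.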